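A few compounds are considered here, and "the series" means these few. Any claim that something is new, unique, unknown or untested is made for them only; others in the source may bear on it.

Measured in an assay for inhibition of serine/threonine-protein kinase PLK2 (Homo sapiens), read by FRET and Z'-LYTE, with a stated time of 1 h; on this read-out lower numbers stand for stronger inhibition and higher numbers for weaker inhibition:
- compound 1, `CC[C@@H]1C(=O)N(C)c2cnc(-n3ccc4cc(C(=O)NCC(C)C)ccc43)nc2N1C1CCCC1`: 18.6 nM
- compound 2, `CC[C@@H]1C(=O)N(C)c2cnc(-n3ccc4cc(C(=O)NC5CCCC5)ccc43)nc2N1C1CCCC1`: 7.06 nM
- compound 3, `CCCNC(=O)c1ccc2c(ccn2-c2ncc3c(n2)N(C2CCCC2)[C@H](CC)C(=O)N3C)c1`: 11.4 nM

Compound 3 stands second highest of the three numbers in this assay. Its nearest neighbour is compound 2, the gap being a 1.6-fold higher number from compound 2 to compound 3 (0.21 log units; within the scatter); the furthest is compound 1, the gap being a 1.6-fold lower number from compound 1 to compound 3 (0.21 log units; within the scatter). Both gaps sit within the scatter, so compound 3 cannot be ordered against either on these numbers. Among the compounds with values here, the only step beyond the scatter in the set is a 2.6-fold lower number from compound 1 to compound 2 (0.42 log units; beyond the scatter), which concerns a ring entering on the amide-type nitrogen.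

Compound 4, `CCNC(=O)c1ccc2c(ccn2-c2ncc3c(n2)N(C2CCCC2)[C@H](CC)C(=O)N3C)c1`, has not yet been measured. It differs from compound 3 by hydrogen in place of methyl on a saturated chain carbon, two bonds along the chain from an amide-type nitrogen. Within the data shown here, the step that bears most directly on this change is the one from compound 1 to compound 3, which also removed a methyl from the chain on the amide-type nitrogen and gave a 1.6-fold lower number from compound 1 to compound 3 (0.21 log units; within the scatter), within the scatter. The step from compound 2 to compound 3, also a shortening of the amide substituent, gave a 1.6-fold higher number from compound 2 to compound 3 (0.21 log units; within the scatter), again within the scatter. Shortening the chain has therefore not moved the number beyond the scatter so far, and no step beyond the scatter is expected here: the estimated change is a 1.2-fold higher number from compound 3 to compound 4 (0.09 log units; within the scatter). Compound 4 is expected to give about 14 nM, with a likely range from 6 nM to 35 nM.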

Compound 4, half-maximal inhibitory concentration: 4.88 nM
Compound 4: middle estimate off by 2.9-fold (0.46 log units), on the high side; the measured number lies below the stated range.
By their numbers in this assay, from the lowest: compounds 4, 2, 3 and 1 (each within the scatter of the next, the first and the last beyond it).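

In this assay, within the data shown here, ethyl in place of propyl on the amide-type nitrogen is the first change confined to this chain to pass beyond the scatter, with a 2.3-fold lower number from compound 3 to compound 4 (0.37 log units; beyond the scatter), while the earlier step from isobutyl to propyl stayed within it. The ethyl amide also extends the span from the isobutyl amide to a 3.8-fold lower number from compound 1 to compound 4 (0.58 log units; beyond the scatter), but it cannot be separated from the cyclopentyl amide, with a 1.4-fold lower number from compound 2 to compound 4 (0.16 log units; within the scatter), so cyclopentyl goes against any reading in which only the shortest chain gives the lowest number. No measurement available here accounts for these steps.

Still open, as far as these compounds go, is whether the number keeps falling with a methyl on the amide-type nitrogen or with the unsubstituted primary amide, or whether ethyl marks the end of the run. Also open, from the compounds shown here alone, is how this nitrogen tolerates a small ring such as cyclopropyl, or a chain ending in a hydroxyl group or an amine, in this assay.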